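The source may report more compounds than this note shows. Statements on the series, on what has been measured and on what is new or still open speak of the compounds shown alone.

Measured compounds:

compound 1, `Cc1cccnc1-c1nc2ccccc2[nH]1`: in a functional assay on the whole organism with Rattus norvegicus as the target, read by paw edema, with a stated time of 3 h, at a dose of 100 mg/kg by the oral route (on this read-out lower numbers stand for less inhibition and higher numbers for more inhibition at the one dose given (going by the name of the read-out)), compound 1 gives 17%
compound 2, `Cc1ccnc(-c2nc3ccccc3[nH]2)c1`: in this assay compound 2 gives -4%
compound 3, `CCCCc1ccc(-c2nc3ccccc3[nH]2)nc1`: in this assay compound 3 gives -16%

Of the three compounds measured in this assay, compound 3 stands lowest. Its nearest neighbour is compound 2, whose number lies higher by a gap beyond the usual scatter; the furthest is compound 1, whose number lies higher still, again beyond the scatter. All three compounds share the same core, and they differ only in the group carried on the six-membered aromatic ring with one nitrogen.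

Compound 4, `CCOC(=O)c1ccc(-c2nc3ccccc3[nH]2)nc1`, has not yet been measured in this assay. It differs from compound 3 in one place: ethoxycarbonyl in place of butyl on an aromatic carbon. No step between two measured compounds is available that would show what such a change does on this read-out, and none of the measured compounds carries a group of this kind, so the expectation for compound 4 rests on the low numbers of all three measured compounds rather than on any shown pattern.

The step of a number 18 percentage points higher from compound 3 to compound 4 (beyond the scatter) is what is expected here, a move upward of roughly the size of the scatter, with no confidence in its direction. For compound 4 the expected value in this assay is 2%, within a range from -18% to 22%.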

Compound 4, a percentage reported as inhibition, in the whole organism at one dose (the size of the read-out at that dose, not a potency): -16%
Estimate against measurement, compound 4: 18 percentage points above; the measured number falls inside the stated range.
By their numbers in this assay, from the lowest: compounds 3 and 4 (each within the scatter of the next); then compound 2; then compound 1.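

In this assay the exchange of butyl for ethoxycarbonyl gives no change at the digits printed from compound 3 to compound 4 (within the scatter) at this aromatic carbon, two atoms from the ring nitrogen, and it is the first step shown at this position. The entering group brings two oxygen atoms, a double bond outside the aromatic rings and two hydrogen-bond acceptors, none of which butyl has, yet at the one dose given the read-out does not separate the two compounds. Nothing measured here explains why these two different groups read alike. The compounds shown leave open whether any other group at this carbon would separate itself from these two on this read-out, for example a carboxylic acid, an amine, or a chain longer than butyl. They also leave open whether the same exchange would read alike on another carbon of this ring, or at another dose.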